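The source may hold more compounds than are shown below. What is called first, only, known or untested is meant among the compounds shown, and "the series" means these compounds.

Compound 1 `CNc1nc(NCc2ccc(NC(=O)c3ccc(F)cc3)cc2)c2ccccc2n1`: 0.35 h
Compound 2 `CN(C)c1nc(NCc2ccc(NC(=O)c3ccc(F)cc3)cc2)c2ccc(C#N)cc2n1`: 0.183 h
Compound 3 `CC(O)c1ccc2c(NCc3ccc(NC(=O)c4ccc(F)cc4)cc3)nc(N(C)C)nc2c1`: 0.1 h

These numbers come from an in vitro ADME assay on microsomes from liver (Rattus norvegicus) for metabolic stability; on this read-out lower numbers stand for a shorter-lived compound and higher numbers for a longer-lived compound. Compound 3, at 0.1 h, lies within the scatter of compound 2 and beyond the scatter under compound 1. Compound 4 `CN(C)c1nc(NCc2ccc(NC(=O)c3ccc(F)cc3)cc2)c2ccc(C=O)cc2n1` has not been measured yet. It carries formyl in place of 1-hydroxyethyl on an aromatic carbon. Within the data shown here, only one measured step swaps a group on that aromatic carbon, a 1.8-fold lower number from compound 2 to compound 3 (0.26 log units; within the scatter), and it stayed within the scatter. One step is thin evidence, but it gives no reason to expect a large move in either direction. The expected change is a 1.2-fold higher number from compound 3 to compound 4 (0.08 log units; within the scatter), which is no step beyond the scatter. For compound 4 the estimated half-life is 0.12 h, with an expected range of 0.05 h to 0.3 h.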

Compound 4, half-life in the Rattus norvegicus assay: 0.05 h
Compound 4: the middle estimate sits 2.4-fold (0.38 log units) above what was measured, within the range that was stated.
By their numbers in the Rattus norvegicus assay, from the lowest: compounds 4, 3, 2 and 1 (each within the scatter of the next, the first and the last beyond it).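

In the Rattus norvegicus assay, a 2.0-fold lower number from compound 3 to compound 4 (0.30 log units; within the scatter), so this swap stays inside the scatter, while a 3.7-fold lower number from compound 2 to compound 4 (0.56 log units; beyond the scatter), and unlike the earlier step on this aromatic carbon, that one passes it. Half-life can therefore shift with the group placed here, at least between cyano and formyl. The swap of 1-hydroxyethyl for formyl shows far more clearly in a physicochemical assay for solubility, at pH 7.4; on this read-out higher numbers stand for higher solubility and lower numbers for lower solubility: the measured solubility of compound 3, 18 ug/mL, and of compound 4, 1 ug/mL, an 18-fold lower number (1.26 log units; beyond the scatter) In the physicochemical assay compound 3 gives 18 ug/mL and compound 4 gives 1 ug/mL.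

From the compounds shown here alone, whether an amine or a carboxylic acid on this aromatic carbon would give a longer half-life while keeping solubility stays open.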